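Sulfanyl triazole phthalimides: shortening the chain on sulfur

The source may hold more compounds than are shown below. What is called first, only, known or untested is meant among the compounds shown, and "the series" means these compounds.

Compound 1, `CCOC(=O)CSc1nnc(C)n1N1C(=O)c2ccccc2C1=O`: in a functional assay on PC-3M cells (Homo sapiens) for cytotoxicity, read by MTT assay, with a stated time of 48 h (a higher number here means a weaker inhibitor, a lower number a stronger inhibitor), compound 1 gives only a limit, > 200000 nM.
Compound 2, `C#CCSc1nnc(C)n1N1C(=O)c2ccccc2C1=O`: in this assay compound 2 likewise gives only a limit, > 200000 nM.

Where compound 2 stands: its value in this assay is a limit of the assay, not a number, so its place among the measured values cannot be fixed. Among the compounds with values here, the one measured step, a step that the two limits leave unreadable from compound 1 to compound 2, is therefore unreadable in size and direction. Within the data shown here, the only evidence on the measured material is the limit of > 200000 nM in this assay, at which 2 of the 2 values shown sit, which holds the single measured step in place.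

The next compound, compound 3, `CSc1nnc(C)n1N1C(=O)c2ccccc2C1=O`, differs from compound 2 by hydrogen in place of ethynyl on a saturated chain carbon bound to a sulfur. Among the measured compounds shown here, no measured step bears on this change in a readable way; nothing points to a gain or a loss beyond the scatter. The same outcome as for compound 2 is expected, since every measured step is fixed at the limit by the limit of > 200000 nM in this assay, at which 2 of the 2 values shown sit. For compound 3 the estimate in this assay is 300000 nM, within 100000 nM to 1000000 nM, most likely reported again as a limit. The expected step is a step that the limit leaves unreadable from compound 2 to compound 3.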

Compound 3, half-maximal inhibitory concentration: > 200000 nM
Compound 3: a limit, no number; the forecaster's own chance of this, stated with the estimate: 85%; the middle value is on the limit's open side.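

In this assay compound 3 gives only a limit, > 200000 nM. No step among compound 1, compound 2 and compound 3 can be read, in size or in direction: the limit of > 200000 nM in this assay, at which 3 of the 3 values shown sit.

The compounds shown leave open whether ethoxycarbonyl, ethynyl or hydrogen on that chain carbon makes any difference to a readable value in this assay.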